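A few compounds are considered here, and "the series" means these few. Any claim that something is new, unique, unknown or untested is made for them only; others in the source may bear on it.

Measured so far in a functional assay (aorta) for inhibition, with Rattus norvegicus as the target; a higher number here means a weaker inhibitor, a lower number a stronger inhibitor: compound 1 `CC(C)(C)c1ccc(C#N)cc1NC(=O)Nc1ccccc1`, 1700000 nM; compound 2 `CC(C)(C)c1ccc(C#N)cc1NC(=O)Nc1ccccn1`, 25700000 nM.

Compound 2 stands highest of the two numbers in this assay; its nearest neighbour is compound 1, and the step of a 15-fold higher number from compound 1 to compound 2 (1.18 log units; beyond the scatter) lies beyond the scatter. Compound 3 `CC(C)(C)c1ccc(C#N)cc1NC(=O)Nc1ccncc1` differs from compound 2 by pyridin-4-yl in place of pyridin-2-yl on an amide-type nitrogen. No measured step compares the two pyridinyl groups directly; the only step shown, a 15-fold higher number from compound 1 to compound 2 (1.18 log units; beyond the scatter), concerns the entry of the ring nitrogen and is large. Compound 3 is therefore expected to sit nearer compound 2 than compound 1, with a modest expected step of a 2.6-fold lower number from compound 2 to compound 3 (0.41 log units; beyond the scatter) in this assay. Compound 3 is estimated at 10000000 nM, range 2000000 nM to 40000000 nM.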

Compound 3, half-maximal inhibitory concentration: 7800000 nM
The estimate for compound 3 lay 1.3-fold (0.11 log units) above the measured number; low and high end bracket the measured number.
By their numbers in this assay, from the lowest: compound 1; then compound 3; then compound 2.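

In this assay, pyridin-4-yl and pyridin-2-yl are not interchangeable on this amide-type nitrogen: the change gives a 3.3-fold lower number from compound 2 to compound 3 (0.52 log units; beyond the scatter) and so recovers part of what the first ring nitrogen cost. Pyridin-4-yl in place of phenyl still gives a 4.6-fold higher number from compound 1 to compound 3 (0.66 log units; beyond the scatter) here, so neither pyridinyl compound matches compound 1 in this series. Nothing available accounts for these differences.

Open is where pyridin-3-yl would fall among these three compounds. Also open, going by these compounds, is whether a phenyl ring carrying an amine or a carboxylic acid would fall below compound 1.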